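Thiophen-3-yl in Place of Pyridin-2-yl on the Shared Core

The source may report more compounds than this note shows. Statements on the series, on what has been measured and on what is new or still open speak of the compounds shown alone.

Three compounds have been measured in a functional assay on HCT-15 cells (Homo sapiens) for cytotoxicity, read by CCK-8 assay and cell counting, with a stated time of 2 days; on this read-out higher numbers stand for weaker inhibition and lower numbers for stronger inhibition:

compound 1 `Oc1ccc(-c2cc(-c3cccc(Cl)c3)nc(-c3ccccn3)c2)cc1`, 28200 nM
compound 2 `Oc1cccc(-c2cc(-c3ccc(Cl)cc3)nc(-c3cccs3)c2)c1`, 9280 nM
compound 3 `Oc1cccc(-c2cc(-c3ccc(Cl)cc3)nc(-c3ccco3)c2)c1`, 10200 nM

Compound 1 stands highest of the three numbers, so it is the weakest inhibitor of the set; compound 3 comes nearest, and compound 2 lies furthest below it, both gaps beyond the scatter. Compound 4 `Oc1ccc(-c2cc(-c3ccsc3)nc(-c3cccc(Cl)c3)c2)cc1` has not yet been measured. It differs from compound 1 by thiophen-3-yl in place of pyridin-2-yl on an aromatic carbon.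

For the measured compounds named here, only one measured step bears on the exchange of one heteroaryl group for another: a 1.1-fold higher number from compound 2 to compound 3 (0.04 log units; within the scatter). Going by the values given here, that step swaps two five-membered groups and leaves the number essentially unchanged, but neither it nor any other measured pair removes a pyridin-2-yl group, so no direct precedent exists. Compounds 2 and 3, which carry a five-membered heteroaryl group, both give lower numbers than compound 1, yet they also differ from compound 1 elsewhere, so their values cannot be read as the effect of this change alone.

Compound 4 is therefore expected to give a number near that of compound 1 or modestly lower, with a 1.8-fold lower number from compound 1 to compound 4 (0.25 log units; within the scatter) as the estimated step. The estimate for compound 4 in this assay is 16000 nM, within a range from 5000 nM to 45000 nM.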

Compound 4, half-maximal inhibitory concentration: 5760 nM
The estimate for compound 4 lay 2.8-fold (0.44 log units) above the measured number, within the range that was stated.
By their numbers in this assay, from the lowest: compounds 4, 2 and 3 (each within the scatter of the next); then compound 1.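

In this assay, thiophen-3-yl in place of pyridin-2-yl, on the aromatic carbon next to the ring nitrogen, gives a 4.9-fold lower number from compound 1 to compound 4 (0.69 log units; beyond the scatter), so this position of the shared core does respond to the exchange of one aromatic group for another, by a step beyond the scatter. The earlier pair could not show this: it exchanged one five-membered group for another, on a differently substituted core, and gave a 1.1-fold higher number from compound 2 to compound 3 (0.04 log units; within the scatter), which lies within the scatter, whereas the new step replaces a six-membered aromatic ring carrying nitrogen with a five-membered one carrying sulfur. No measurement at hand accounts for the size or direction of this step.

For the compounds shown here, the single pair leaves open whether the lower number follows from the change in ring size, the loss of the ring nitrogen or the arrival of the sulfur, a question that an unsubstituted phenyl or a pyridin-3-yl group at this position could help to separate. It also leaves open whether a non-aromatic group such as morpholine would be tolerated here, and whether the same exchange would give a similar step with the chlorophenyl and hydroxyphenyl groups arranged as in compound 2.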